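Chloro for nitro on a weakly active compound

This account rests on a few compounds, and the source may have more. Where it says the series, first, only, none or still open, it means among the compounds named here.

Values in a functional assay on U-251 cells (Homo sapiens) for antiproliferative activity, read by MTT assay, with a stated time of 24 h; on this read-out higher numbers stand for weaker inhibition and lower numbers for stronger inhibition:
- Compound 1 `COc1cccc(C(=O)Oc2ccc3c(=O)c(-c4cc(OC)c(OC)cc4OC)coc3c2)c1`: > 10000 nM (a limit)
- Compound 2 `COc1cc(OC)c(-c2coc3cc(OCc4ccc([N+](=O)[O-])cc4)ccc3c2=O)cc1OC`: 9400 nM

In this assay, among the compounds with values here, compound 2 gives 9400 nM, the only true number so far. Compound 1 reads > 10000 nM, which is a limit of the assay and not a number.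

Compound 3 `COc1cc(OC)c(-c2coc3cc(OCc4ccc(Cl)cc4)ccc3c2=O)cc1OC` departs from compound 2 in one place: chloro in place of nitro on an aromatic carbon. Within the data shown here, only one measured step exists, an at least 1.0-fold lower number from compound 1 to compound 2 (0.02 log units; that floor lies within the scatter). It exchanges the whole group on the oxygen and stays within the scatter, so it offers no sign that this smaller change will matter. No shift beyond the scatter is therefore expected in this assay. The expected 1.2-fold lower number from compound 2 to compound 3 (0.07 log units; within the scatter) stays within that scatter. Compound 3 is estimated at 8000 nM, with an expected range of 3000 nM to 16000 nM.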

Compound 3, half-maximal inhibitory concentration: 470 nM
Compound 3: middle estimate off by 17-fold (1.23 log units), on the high side; measured number outside the range, below it.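

Going from 4-nitrobenzyl to 4-chlorobenzyl gives a 20-fold lower number from compound 2 to compound 3 (1.30 log units; beyond the scatter) in this assay, so a single group on an aromatic carbon, para to a large group, can move this read-out well beyond the scatter, which the earlier step did not show. Set against the (3-methoxyphenyl)carbonyl group on the oxygen, the 4-chlorobenzyl group now gives an at least 21-fold lower number from compound 1 to compound 3 (1.32 log units; beyond the scatter), and this step is only a floor, since compound 1 stands at a limit of the assay and not a number: the limit of > 10000 nM in this assay, at which 1 of the 3 values shown sits. The values shown do not tell why chloro and nitro differ so much here.

As far as these compounds go, it stays open whether an amine, a methoxy group or a carboxylic acid at this place would match chloro. From the compounds shown here alone, this exchange is also known from a single pair, so whether it carries over to another group on the oxygen remains unknown.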